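The source may hold more compounds than are shown below. What is called first, only, known or untested is meant among the compounds shown, and "the series" means these compounds.

Measured so far in a functional assay for inhibition, with Homo sapiens as the target; a lower number here means a stronger inhibitor, a higher number a weaker inhibitor:
- compound 1, `CCCc1nnc(O)n2c(CCC)nc(C)c12`, where compound 1 gives 16000 nM
- compound 2, `Cc1nc(C)n2c(O)nncc12`, where compound 2 gives > 48000 nM, a limit of the assay and not a number

Compound 2 thus stands at the weak end of what this assay reports: its value is the limit of > 48000 nM in this assay, at which 1 of the 2 values shown sits, so only a floor of potency is known for it, and the true concentration needed may lie anywhere beyond that limit. Among the measured compounds shown here, compound 1, the only compound with a numerical value, sits well inside the measurable range.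

The unmeasured compound 3, `CCCc1nnc(O)n2c(C)nc(C)c12`, is reached from compound 2 by a single change: propyl in place of hydrogen on an aromatic carbon. For the measured compounds named here, compound 3 carries the propyl that compound 1 also bears on that ring, while keeping the methyl of compound 2 on the other ring; no measured step for this pair exists, so its size can only be guessed.

The expected step, an at least 1.6-fold lower number from compound 2 to compound 3 (0.20 log units; that floor lies within the scatter), is estimated to run toward stronger inhibition, because compound 1, which carries propyl at the same place, gives 16000 nM. Compound 3 is expected to give 30000 nM, within 10000 nM to 90000 nM.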

Compound 3, half-maximal inhibitory concentration: > 48000 nM
Compound 3 was reported as a limit; the forecaster's own chance of this, stated with the estimate: 35%; at least 1.6-fold (0.20 log units) between middle value and limit.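

In this assay compound 3 gives > 48000 nM, a limit of the assay and not a number, and this limit now applies to a second compound: the limit of > 48000 nM in this assay, at which 2 of the 3 values shown sit.

Propyl in place of hydrogen on the aromatic carbon is thus not enough on its own to bring a compound into the measurable range, although the step between the two compounds at the limit cannot be read. Among the compounds shown here, the one readable step is hydrogen in place of ethyl on a saturated chain carbon bound to an aromatic carbon, an at least 3.0-fold higher number from compound 1 to compound 3 (0.47 log units; beyond the scatter), so within this pair the measurable value goes with the longer chain on the other ring, the propyl of compound 1, and not with the methyl of compound 3.

The compounds shown leave open how far past the limit compound 2 and compound 3 lie, and so how large the true step is. They also leave open whether a butyl chain or an amine in place of that methyl would give a lower number than compound 1.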